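This account rests on a few compounds, and the source may have more. Where it says the series, first, only, none or still open, it means among the compounds named here.

Compound 2, `CC(=O)Nc1cc(NC(=O)Nc2ccc(Cl)c(C(F)(F)F)c2)ccc1C`, gives 1100 nM in a functional assay on A375P cells (Homo sapiens) for antiproliferative activity (a higher number here means a weaker inhibitor, a lower number a stronger inhibitor), the second highest of the three numbers in hand. Compound 1, `CC(=O)Nc1cc(NC(=O)Nc2ccc(Cl)c(Cl)c2)ccc1C`, gives 2100 nM, and the step of a 1.9-fold lower number from compound 1 to compound 2 (0.28 log units; within the scatter) is a change on the aryl ring that leaves the amide untouched. Compound 3, `Cc1ccc(NC(=O)Nc2cc(C(F)(F)F)cc(C(F)(F)F)c2)cc1NC(=O)c1ccccc1`, gives 162 nM; it carries a benzamido group but also a different aryl ring, so its gap from compound 2 rests on two changes at once and cannot be read as one step. Compound 4, `Cc1ccc(NC(=O)Nc2ccc(Cl)c(C(F)(F)F)c2)cc1NC(=O)c1ccccc1`, differs from compound 2 by phenyl in place of methyl on a carbonyl carbon, acetamido becoming benzamido. For the measured compounds named here, no measured step isolates this change, and the one recorded step bears on the aryl ring rather than on the amide. The lower number of compound 3, which shares the benzamido group, gives some reason to expect the number to fall, though with wide uncertainty. Compound 4 is therefore expected to give 350 nM, with a range from 100 nM to 1200 nM. The expected step is a 3.1-fold lower number from compound 2 to compound 4 (0.50 log units; beyond the scatter).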

Compound 4, half-maximal inhibitory concentration: 1300 nM
Compound 4: middle estimate off by 3.7-fold (0.57 log units), on the low side, outside the stated range (above it).
By their numbers in this assay, from the lowest: compound 3; then compounds 2, 4 and 1 (each within the scatter of the next).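

In this assay the change from acetamido to benzamido on this aryl ring comes out as a 1.2-fold higher number from compound 2 to compound 4 (0.07 log units; within the scatter), so this position accepts a phenyl on the carbonyl carbon with no change that can be told from the scatter. Compound 4 shares the benzamido group with compound 3, which gives 162 nM, so the benzamido group alone does not bring that number with it, and the number of compound 3 cannot be credited to the amide. Nothing in hand explains why the swap leaves the number where it stands.

Going by these compounds, it remains open whether the same swap would behave alike on the aryl ring of compound 3. Also open, on these data alone, is whether an amine, a carboxylic acid or a longer chain on this carbonyl carbon would move the number.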